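The compounds below may be only part of what the source reports. "The series", "measured", "known", "first", "only" and "open" are said of these compounds alone.

Three measured compounds share one core and differ only in the chain that ends in the isothiocyanate group. Compound 1 `CN(C)C(=O)c1cc2cnc(Nc3ccc(C(=O)NCCCCN=C=S)cc3)nc2n1C1CCCC1` gives 102% in a functional assay on A549 cells (Homo sapiens) for inhibition, read by CCK-8 assay, with a stated time of 72 h, tested at 10 uM; a lower number here means a weaker effect, a higher number a stronger effect of the compound at the concentration tested. Compound 2 `CN(C)C(=O)c1cc2cnc(Nc3ccc(C(=O)NCCCCCN=C=S)cc3)nc2n1C1CCCC1` gives 100% in this assay, and compound 3 `CN(C)C(=O)c1cc2cnc(Nc3ccc(C(=O)NCCCCCCCN=C=S)cc3)nc2n1C1CCCC1` gives 101% in this assay. On these numbers compound 2 stands lowest of the three, but each of its neighbours lies within the scatter of it, as the steps of a number 2 percentage points lower from compound 1 to compound 2 (within the scatter) and a number 1 percentage points higher from compound 2 to compound 3 (within the scatter) show, and the step of a number 1 percentage points lower from compound 1 to compound 3 (within the scatter) is equally flat. All three values sit at full inhibition at the concentration tested.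

Compound 4 `CN(C)C(=O)c1cc2cnc(Nc3ccc(C(=O)NCCCCCN=C=S)cc3F)nc2n1C1CCCC1` has not been measured yet. It differs from compound 2 by fluoro in place of hydrogen on an aromatic carbon. Within the data shown here, none of the measured steps touches the aromatic ring; all three lengthen or shorten the chain and all three lie within the scatter, so no measured step bears directly on this change, and the data give only a flat plateau at the top of the read-out. The expectation for this assay is therefore no step beyond the scatter. Compound 4 is expected to give about 99%, within a range from 88% to 105%. That estimate means a step of a number 1 percentage points lower from compound 2 to compound 4 (within the scatter).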

Compound 4, a percentage reported as inhibition, at one concentration (the size of the read-out at that concentration, not a potency): 15.6%
Estimate against measurement, compound 4: 83.4 percentage points above; measured number below the stated range.
By their numbers in this assay, from the lowest: compound 4; then compounds 2, 3 and 1 (each within the scatter of the next).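

In this assay, the replacement of a hydrogen by fluoro on an aromatic carbon, ortho to a large group, gives a number 84.4 percentage points lower from compound 2 to compound 4 (beyond the scatter), whereas changing the chain gave only a number 2 percentage points lower from compound 1 to compound 2 (within the scatter). The flat values of the chain series therefore did not extend to this ring position, where a single fluorine atom is enough to take compound 4 far off the plateau at the concentration tested. Nothing measured here accounts for this loss of inhibition.

The compounds shown leave open whether the loss is specific to fluoro or would also follow from a chloro, methyl or methoxy group on the same carbon, and whether fluoro on another carbon of this ring would have the same effect. They also leave open whether the same change would act alike on the shorter chain of compound 1 or the longer chain of compound 3, and, with a single concentration as the read-out, how potent compound 4 and the other compounds are.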